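Swapping a Ring Amine for a Smaller One

The source may hold more compounds than are shown below. What is called first, only, known or untested is meant among the compounds shown, and "the series" means these compounds.

Of the compounds shown here, three sharing one core have been tested for their ability to slow the growth of stomach cancer cells. Compound 1 `COc1cc2oc(-c3ccccc3)cc(=O)c2c(O)c1OCCCN1CCN(C)CC1` gives 31300 nM in a functional assay on BCG823 cells (Homo sapiens) for antiproliferative activity, read by MTT assay, with a stated time of 48 h; on this read-out higher numbers stand for weaker inhibition and lower numbers for stronger inhibition. Compound 3 `COc1cc2oc(-c3ccccc3)cc(=O)c2c(O)c1OCCCN1CCCC1` gives 6500 nM, which is a 4.8-fold lower number from compound 1 to compound 3 (0.68 log units; beyond the scatter). Compound 2 `O=c1cc(-c2ccccc2)oc2cc(OCc3ccccc3)c(OCCCCN3CCCCC3)c(O)c12` gives 3000 nM, the lowest of the three numbers and so the strongest inhibitor among them. Compound 4 `CN(C)CCCOc1c(OCc2ccccc2)cc2oc(-c3ccccc3)cc(=O)c2c1O` has not yet been measured; it differs from compound 2 in one place: dimethylamino in place of (piperidin-1-yl)methyl on a saturated chain carbon, three bonds along the chain from an oxygen on an aromatic ring. For the measured compounds named here, the only measured step that also exchanges the group at this place, from compound 1 to compound 3, was modest yet beyond the scatter, so a modest step is expected here as well, most likely toward a higher number. Compound 4 is therefore expected to give 4500 nM, within a range from 1500 nM to 12000 nM, which would be a step of a 1.5-fold higher number from compound 2 to compound 4 (0.18 log units; within the scatter).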

Compound 4, half-maximal inhibitory concentration: 5500 nM
Beside the measured number, compound 4's estimate is 1.2-fold (0.09 log units) below it; measured number inside the range.
By their numbers in this assay, from the lowest: compounds 2, 4 and 3 (each within the scatter of the next, the first and the last beyond it); then compound 1.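

In this assay, dimethylamino in place of (piperidin-1-yl)methyl gives a 1.8-fold higher number from compound 2 to compound 4 (0.26 log units; within the scatter) and so leaves the number unchanged within the scatter. In this pair, then, the piperidine ring is not needed to hold this level of activity, whereas the amine exchange of a 4.8-fold lower number from compound 1 to compound 3 (0.68 log units; beyond the scatter) moved the number beyond the scatter. Nothing measured here explains this difference between the two steps. Still open, as far as these compounds go, is how a morpholine ring or a primary amine would fare at this place, and whether a carboxylic acid could stand in for the amine.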